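The source may report more compounds than this note shows. Statements on the series, on what has been measured and on what is new or still open speak of the compounds shown alone.

Of the compounds shown here, three have been measured in an assay for inhibition of steroid 17-alpha-hydroxylase/17,20 lyase (Homo sapiens), using NADPH, tested at 2 uM; on this read-out lower numbers stand for a weaker effect and higher numbers for a stronger effect at the one concentration tested. Compound 1 `c1cncc(-c2ccc(Cn3ccnc3)cc2)c1` gives 14%. Compound 3 `ClCc1ccc(-c2ccc(Cn3ccnc3)cc2)cn1`, which carries chloromethyl in place of hydrogen on an aromatic carbon, gives 24%, a change described by a number 10 percentage points higher from compound 1 to compound 3 (within the scatter). Compound 2 `c1cn(Cc2ccc(-c3ccoc3)cc2)cn1`, with furan-3-yl in place of pyridin-3-yl on an aromatic carbon, gives 29%; this step is a number 15 percentage points higher from compound 1 to compound 2 (beyond the scatter). Compound 2 therefore holds the highest of the three numbers, though its gap to compound 3 is within the scatter and only its gap to compound 1 lies beyond it.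

The account now turns to compound 4 `c1cn(Cc2ccc(-c3cncnc3)cc2)cn1`, which differs from compound 2 as follows: pyrimidin-5-yl in place of furan-3-yl on an aromatic carbon. For the measured compounds named here, the only measured step that bears on this change is the one from compound 1 to compound 2, in which a six-membered ring with one nitrogen gave way to furan-3-yl and the read-out rose by a number 15 percentage points higher from compound 1 to compound 2 (beyond the scatter). Compound 4 reverses that direction, putting a six-membered ring with two nitrogens in place of furan-3-yl. A return toward the level of compound 1 is therefore expected, of about a number 12 percentage points lower from compound 2 to compound 4 (beyond the scatter) in this assay. Compound 4 is thus estimated at 17%, within a range of 5% to 30%.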

Compound 4, a percentage reported as inhibition, at one concentration (the size of the read-out at that concentration, not a potency): 3%
Compound 4: the middle estimate sits 14 percentage points above what was measured; the whole stated range lies above it.
By their numbers in this assay, from the lowest: compound 4; then compounds 1, 3 and 2 (each within the scatter of the next, the first and the last beyond it).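

With pyrimidin-5-yl on this aromatic carbon, para to a group of 6 heavy atoms, this assay shows that the read-out does not merely return to the level of the pyridin-3-yl compound, with a number 11 percentage points lower from compound 1 to compound 4 (beyond the scatter) and, against the furan-3-yl compound, a number 26 percentage points lower from compound 2 to compound 4 (beyond the scatter) as the two new steps. The three groups tested at this one position therefore now fall in a single order from the highest number to the lowest: furan-3-yl, pyridin-3-yl, pyrimidin-5-yl, although three compounds are too few to establish a trend. The data offer no measurement that would explain this fall.

The compounds shown leave open whether the order depends on the hetero atoms or on ring size, which a plain phenyl, a thiophen-3-yl or a pyrimidin-2-yl group at the same position could help to separate. They also leave open whether chloromethyl, or a group such as an amine or a carboxylic acid, would change the read-out when carried on the pyrimidin-5-yl or furan-3-yl ring.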